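Expected Cytotoxicity of Compound 4 After Losing a Methoxy Group

The compounds below may be only part of what the source reports. "The series", "measured", "known", "first", "only" and "open" are said of these compounds alone.

Of the compounds shown here, three sharing one core have been tested in a functional assay on A549 cells (Homo sapiens) for cytotoxicity, read by sulforhodamine B assay, with a stated time of 48 h, tested at 0.01 uM; a higher number here means a weaker effect of the compound at the concentration tested, a lower number a stronger effect. Compound 1 `COc1ccc(-c2cc(/C=C/C(=O)c3ccc(N)cc3)[nH]n2)cc1` gives 101%, compound 2 `COc1cc(-c2cc(/C=C/C(=O)c3ccc(N)cc3)[nH]n2)cc(OC)c1OC` gives 96%, and compound 3 `COc1cc(-c2cc(/C=C/C(=O)c3ccc(F)c(F)c3)[nH]n2)cc(OC)c1OC` gives 101%. Compound 2 holds the smallest of the three numbers, yet compound 1 and compound 3 both sit within the scatter of it, so no real difference is shown. For the measured compounds named here, the only measured single-point step, a number 5 percentage points higher from compound 2 to compound 3 (within the scatter), stayed within the scatter. Compound 4 `COc1ccc(-c2cc(/C=C/C(=O)c3ccc(N)cc3)[nH]n2)cc1OC` differs from compound 2 by hydrogen in place of methoxy on an aromatic carbon. Going by the values given here, no measured step removes a methoxy group, so that step bears only loosely here. With compound 2 at 96% and all three numbers close together, the expected change is a number 2 percentage points higher from compound 2 to compound 4 (within the scatter). Compound 4 is therefore estimated at 98%, between 88% and 108%.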

Compound 4, a percentage reported as activity, at one concentration (the size of the read-out at that concentration, not a potency): 97%
Compound 4: the middle estimate sits 1 percentage points above what was measured; low and high end bracket the measured number.
By their numbers in this assay, from the lowest: compounds 2, 4, 1 and 3 (each within the scatter of the next).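

In this assay, a number 1 percentage points higher from compound 2 to compound 4 (within the scatter) with hydrogen in place of methoxy, and a number 4 percentage points lower from compound 1 to compound 4 (within the scatter) with methoxy in place of hydrogen. Both steps lie within the scatter, so neither swap on this aromatic ring shows a real effect at this single concentration. No other data bear on this result.

The compounds shown leave open whether this position matters under conditions where a compound clearly reduces the read-out. On these data alone, whether a hydroxyl group or a chlorine atom on this carbon would behave like methoxy or hydrogen also stays open.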